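Pyrrolidinyl for Diethylamino on the Chain Carbon

The source may hold more compounds than are shown below. What is called first, only, known or untested is meant among the compounds shown, and "the series" means these compounds.

In a functional assay on PC-3 cells (Homo sapiens) for antiproliferative activity, read by MTT assay, with a stated time of 72 h (on this read-out lower numbers stand for stronger inhibition and higher numbers for weaker inhibition), compound 3 `CCN(CC)C/C=C/C(=O)Nc1cc2c(N3CCc4ccccc43)ncnc2cc1O[C@@H]1CCOC1` gives 5780 nM, the second highest of the three numbers; compound 1 `CC/C=C/C(=O)Nc1cc2c(N3CCc4ccccc43)ncnc2cc1O[C@@H]1CCOC1` at 9590 nM lies within the scatter of it, while compound 2 `COc1cc2ncnc(N3CCc4ccccc43)c2cc1NC(=O)/C=C/CN1CCCC1` at 2620 nM lies beyond it. Compound 4 `O=C(/C=C/CN1CCCC1)Nc1cc2c(N3CCc4ccccc43)ncnc2cc1O[C@@H]1CCOC1` differs from compound 3 by pyrrolidin-1-yl in place of diethylamino on a saturated chain carbon bound to a double-bonded chain carbon. Going by the values given here, the one measured step at this place, a 1.7-fold lower number from compound 1 to compound 3 (0.22 log units; within the scatter), stayed within the scatter. Compound 2 also carries pyrrolidin-1-yl there, but it differs from compound 4 in a second place as well, so its value only hints at the direction. The step expected in this assay is a 1.4-fold lower number from compound 3 to compound 4 (0.16 log units; within the scatter), a move that may not exceed the scatter. Compound 4 is therefore estimated at 4000 nM, with a range from 1500 nM to 10000 nM.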

Compound 4, half-maximal inhibitory concentration: 1510 nM
The estimate for compound 4 lay 2.6-fold (0.42 log units) above the measured number, within the range that was stated.
By their numbers in this assay, from the lowest: compounds 4 and 2 (each within the scatter of the next); then compounds 3 and 1 (each within the scatter of the next).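

Pyrrolidin-1-yl on this saturated chain carbon brings a 3.8-fold lower number from compound 3 to compound 4 (0.58 log units; beyond the scatter) in this assay, so two amines with the same count of heavy atoms are told apart here, a ring against no ring. Against methyl at this place, the change gives a 6.4-fold lower number from compound 1 to compound 4 (0.80 log units; beyond the scatter) and so passes beyond the scatter. With pyrrolidin-1-yl in place, oxolan-3-yl for methyl on the oxygen on an aromatic ring gives a 1.7-fold lower number from compound 2 to compound 4 (0.24 log units; within the scatter) and stays within the scatter. Nothing at hand explains the difference between the two amines. Going by these compounds, whether a larger ring amine such as piperidin-1-yl or morpholin-4-yl would follow pyrrolidin-1-yl remains open.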